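From pyrrolidin-1-yl to 4-methylpiperazin-1-yl on compound 3

The source may report more compounds than this note shows. Statements on the series, on what has been measured and on what is new or still open speak of the compounds shown alone.

In a functional assay on MCF7 cells (Homo sapiens) for inhibition, read by MTT assay, with a stated time of 72 h (a higher number here means a weaker inhibitor, a lower number a stronger inhibitor), compound 1 (`C/C1=C\CC[C@@]2(C)O[C@@H]2[C@H]2OC(=O)[C@@H](CN3CCCC3)[C@@H]2C[C@H]1O`) gives 21000 nM and compound 2 (`C/C1=C\CC[C@@]2(C)O[C@@H]2[C@H]2OC(=O)[C@@H](CN3CCN(C)CC3)[C@@H]2C[C@H]1O`) gives 33000 nM. Compound 3 (`C/C1=C\CC[C@@]2(C)O[C@@H]2[C@H]2OC(=O)[C@@H](CN3CCCC3)[C@@H]2C[C@@H]1O`) gives 18000 nM, which lies within the scatter of both others, so the three values carry no order.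

Compound 4 (`C/C1=C\CC[C@@]2(C)O[C@@H]2[C@H]2OC(=O)[C@@H](CN3CCN(C)CC3)[C@@H]2C[C@@H]1O`) is not yet measured. Its difference from compound 3 is 4-methylpiperazin-1-yl in place of pyrrolidin-1-yl on a saturated chain carbon bound to a saturated ring carbon, which amounts to (pyrrolidin-1-yl)methyl giving way to (4-methylpiperazin-1-yl)methyl.

The same exchange has been measured once, in the other drawn configuration: a 1.6-fold higher number from compound 1 to compound 2 (0.20 log units; within the scatter). The remaining measured step is a 1.2-fold lower number from compound 1 to compound 3 (0.07 log units; within the scatter), and it goes with the fact that compounds 1 and 3 differ only in the configuration as drawn. That step offers no reason to expect the exchange to behave differently on compound 3, so the first step serves as the guide, and no change beyond the scatter is expected in this assay.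

The expected step is a 1.5-fold higher number from compound 3 to compound 4 (0.18 log units; within the scatter).

Compound 4 is estimated at 27000 nM, with an expected range of 15000 nM to 50000 nM.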

Compound 4, half-maximal inhibitory concentration: 22000 nM
Beside the measured number, compound 4's estimate is 1.2-fold (0.09 log units) above it; the measured number falls inside the stated range.
By their numbers in this assay, from the lowest: compounds 3, 1, 4 and 2 (each within the scatter of the next).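

In this assay, the exchange of pyrrolidin-1-yl for 4-methylpiperazin-1-yl on a saturated chain carbon bound to a saturated ring carbon can now be read in both drawn configurations, with a 1.2-fold higher number from compound 3 to compound 4 (0.09 log units; within the scatter) joining the earlier step, and the two steps agree: the same change on two cores in this assay, a 1.6-fold higher number (0.20 log units; within the scatter) from compound 1 to compound 2 and a 1.2-fold higher number (0.09 log units; within the scatter) from compound 3 to compound 4, 1.3-fold (0.11 log units) apart, within the scatter of two such steps. The change of drawn configuration can likewise now be read with both groups, and with 4-methylpiperazin-1-yl in place it gives a 1.5-fold lower number from compound 2 to compound 4 (0.18 log units; within the scatter): the fact that compounds 2 and 4 differ only in the configuration as drawn. Across all four steps in this set, neither change moves the number beyond the scatter, and no step goes against this.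

Still open, going by these compounds, is whether any other group at this place, such as morpholin-4-yl, dimethylamino or a carboxylic acid, would move the number beyond the scatter. Also open, on these data alone, is how these compounds read in any assay other than this assay.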